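The source may hold more compounds than are shown below. What is called first, only, known or untested is meant among the compounds shown, and "the series" means these compounds.

Measured in a functional assay for inhibition, with Homo sapiens as the target; a higher number here means a weaker inhibitor, a lower number a stronger inhibitor:
- Compound 1 `Cc1cc2c(cc1C(=O)N=C(N)N)S(=O)(=O)CC2C(C)C`: 77 nM
- Compound 2 `CO/N=C1\CS(=O)(=O)c2cc(C(=O)N=C(N)N)c(C)cc21`: 521 nM

Compound 1 has the lower of these two numbers, so it is the stronger inhibitor of the pair. Compound 3 `Cc1cc2c(cc1C(=O)N=C(N)N)S(=O)(=O)CC2O` has not yet been measured. It differs from compound 1 by one change, hydroxy in place of isopropyl on a saturated ring carbon. Within the data shown here, no measured pair isolates this change, so the expectation is loose. Compound 2 also lacks the isopropyl and gives 521 nM, a weaker result. The expected step in this assay is therefore upward and beyond the scatter, a 7.8-fold higher number from compound 1 to compound 3 (0.89 log units; beyond the scatter). For compound 3 the estimated value is 600 nM, with an expected range of 150 nM to 2500 nM.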

Compound 3, half-maximal inhibitory concentration: 1050 nM
Estimate against measurement, compound 3: 1.8-fold (0.24 log units) below; the measured number falls inside the stated range.
By their numbers in this assay, from the lowest: compound 1; then compounds 2 and 3 (each within the scatter of the next).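

In this assay, among these compounds, the swap of hydroxy for isopropyl on a saturated ring carbon gives a 14-fold higher number from compound 1 to compound 3 (1.13 log units; beyond the scatter) and is the first change here read in isolation. It shows that the group at this one place on the shared core can move the number by a large step. No measurement at hand bears on the cause of this step.

As far as these compounds go, whether the step comes from losing the isopropyl or from gaining the hydroxy stays open. A methyl or a methoxy on the same carbon would help tell these apart.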